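Expected Cytotoxicity of Compound 4 After a Smaller Phenol

The compounds below may be only part of what the source reports. "The series", "measured", "known", "first", "only" and "open" are said of these compounds alone.

Compound 1 `CN(C)CCn1cnnc1-c1cc(Oc2ccc(NC(=O)N/N=C/c3ccc(O)c(Br)c3)cc2F)ccn1`: 12400 nM
Compound 2 `CN(C)CCn1cnnc1-c1cc(Oc2ccc(NC(=O)N/N=C/c3ccc(F)cc3)cc2F)ccn1`: 2310 nM
Compound 3 `COc1cc(/C=N/NC(=O)Nc2ccc(Oc3ccnc(-c4nncn4CCN(C)C)c3)c(F)c2)ccc1O`: > 100000 nM

All three compounds share one core and differ only in the aryl group attached to the carbon with a double bond to nitrogen. They were tested in a functional assay on U-87MG ATCC cells (Homo sapiens) for cytotoxicity, read by MTT assay, with a stated time of 72 h; on this read-out lower numbers stand for stronger inhibition and higher numbers for weaker inhibition. Compound 3 did not reach a number at all and is recorded as a limit of the assay, (the limit of > 100000 nM in this assay, at which 1 of the 3 values shown sits). Compound 4 `CN(C)CCn1cnnc1-c1cc(Oc2ccc(NC(=O)N/N=C/c3cccc(O)c3)cc2F)ccn1` is not yet measured; it differs from compound 3 by 3-hydroxyphenyl in place of 4-hydroxy-3-methoxyphenyl on a carbon with a double bond to nitrogen.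

Among the compounds with values here, two measured steps bear on this change. The step of an at least 43-fold higher number from compound 2 to compound 3 (1.63 log units; beyond the scatter) shows that the 4-hydroxy-3-methoxyphenyl group sits far weaker than the 4-fluorophenyl group. The step of an at least 8.0-fold higher number from compound 1 to compound 3 (0.90 log units; beyond the scatter) shows that the methoxy group alone, compared with bromo, pushes the number past the limit. Compound 1, which keeps a hydroxyl on its aryl group, gives 12400 nM. Compound 4 also keeps a hydroxyl but loses the methoxy group, so a lower number than the limit of compound 3 is expected, roughly an at least 5.0-fold lower number from compound 3 to compound 4 (0.69 log units; beyond the scatter). Compound 4 is therefore estimated at 20000 nM, with a range from 5000 nM to 80000 nM.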

Compound 4, half-maximal inhibitory concentration: > 100000 nM
Compound 4: a limit, no number; the forecaster's own chance of this, stated with the estimate: 25%; middle value at least 5.0-fold (0.69 log units) away from the limit.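

In this assay compound 4 gives > 100000 nM, which is a limit of the assay and not a number, so taking away the methoxy group does not by itself bring back a readable value. The 3-hydroxyphenyl group falls far behind the 4-fluorophenyl group, with an at least 43-fold higher number from compound 2 to compound 4 (1.63 log units; beyond the scatter), and also behind the 3-bromo-4-hydroxyphenyl group, with an at least 8.0-fold higher number from compound 1 to compound 4 (0.90 log units; beyond the scatter); among these four compounds a hydroxyl on the aryl group does not settle the outcome, as compound 1 carries one and still gives a number, while compound 3 and compound 4 do not. Any step between compound 3 and compound 4 cannot be read, and nothing can be said about which of the two is stronger, as both stand at the same limit: the limit of > 100000 nM in this assay, at which 2 of the 4 values shown sit.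

On these data alone, how far compound 3 and compound 4 lie beyond that limit stays open, as does whether the bromo group accounts for the gap between compound 1 and compound 4. Also open, as far as these compounds go, is what a chloro group, an amine or a carboxylic acid on the same aryl group would do to cytotoxicity in these cells.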